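This account rests on a few compounds, and the source may have more. Where it says the series, first, only, none or still open, it means among the compounds named here.

Measured compounds:
- compound 1, `Cc1c(N(C)C)nc(CCCCCCCCCCO)c(O)c1C` — 3%
- compound 2, `CCCCCCCCCCc1nc(N(C)C)c(C)c(C)c1O` — 13%

In a functional assay on cells (Lymphocyte), read by a luciferase reporter and ATP content, with a stated time of 48 h, tested at 25 uM (a higher number here means a weaker effect of the compound at the concentration tested, a lower number a stronger effect), compound 1 gives 3% and compound 2 gives 13%. On these two numbers compound 2 cannot be told apart from compound 1: a number 10 percentage points higher from compound 1 to compound 2 (within the scatter). Both therefore read as strong effects at the concentration tested.

Compound 3, `CCCCCCCCCCCCCCCCCCCc1nc(N(C)C)c(C)c(C)c1O`, is the next member to go into this assay. Relative to compound 2 the change is nonyl in place of hydrogen on a saturated chain carbon, ten or more bonds along the chain from an aromatic carbon. Going by the values given here, no measured step concerns a chain of this kind; the only step available, the one from compound 1 to compound 2, exchanges a hydroxy for hydrogen and does not lengthen the chain, so it offers no direct guide. With nothing pointing either way, the expectation is that the change is a number 7 percentage points higher from compound 2 to compound 3 (within the scatter), a step not beyond the scatter, though the range is kept wide.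

Compound 3 is estimated at 20%, between 0% and 60%.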

Compound 3, a percentage reported as activity, at one concentration (the size of the read-out at that concentration, not a potency): 99%
Estimate against measurement, compound 3: 79 percentage points below, and the stated range ends below it.
By their numbers in this assay, from the lowest: compounds 1 and 2 (each within the scatter of the next); then compound 3.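

In this assay, going by these compounds alone, this place on the chain is sensitive to added length: nonyl in place of hydrogen on a saturated chain carbon, ten or more bonds along the chain from an aromatic carbon, gives a number 86 percentage points higher from compound 2 to compound 3 (beyond the scatter), the first step beyond the scatter. Nonyl in place of hydroxy at the same place gives a number 96 percentage points higher from compound 1 to compound 3 (beyond the scatter), so the strong effect seen with hydroxy or hydrogen there does not carry over to the longer chain. Nothing available gives a reason for this loss of effect.

Open, on these data alone, is the chain length at which the effect falls away, and whether a shorter chain such as hexyl, in place of the decyl chain of compound 2, keeps it. Also open, as far as these compounds go, is how an amine or a carboxylic acid at this same place would read.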